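This account rests on a few compounds, and the source may have more. Where it says the series, first, only, none or still open, it means among the compounds named here.

Compound 2, with structure `CCN1CCCC1CNC(=O)c1cc(NS(C)(=O)=O)c(Cl)cc1OC`, is the one of the two measured compounds that gives an actual number in a functional assay on the whole organism for inhibition, with Mus musculus as the target; a lower number here means that less compound is needed, a higher number that more compound is needed for the effect: compound 2 reaches 9.1 mg/kg. Compound 1, `CCN1CCCC1CNC(=O)c1cc(NS(C)(=O)=O)ccc1OC`, differs from it by carrying hydrogen where compound 2 carries chloro on an aromatic carbon; in this assay compound 1 returns > 50 mg/kg, which is a limit of the assay rather than a number. As far as these compounds go, the step is an at least 5.4-fold lower number from compound 1 to compound 2 (0.73 log units; beyond the scatter), but it rests on (the limit of > 50 mg/kg in this assay, at which 1 of the 2 values shown sits), so its true size stays open. Compound 3, `CCN1CCCC1CNC(=O)c1cc(N(C)S(N)(=O)=O)c(Cl)cc1OC`, keeps the chloro group and alters a different position: methyl(sulfamoyl)amino in place of methanesulfonamido on an aromatic carbon. Within the data shown here, no measured step covers this kind of exchange, so no direction can be read from the data, and the expectation is a step of about a 1.3-fold higher number from compound 2 to compound 3 (0.12 log units; within the scatter), within the scatter. Compound 3 is therefore estimated at 12 mg/kg, with a range from 4 mg/kg to 40 mg/kg.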

Compound 3, dose for half-maximal effect: > 50 mg/kg
Compound 3 ended at the assay's limit; the forecaster's own chance of this, stated with the estimate: 20%; at least 4.1-fold (0.61 log units) between middle value and limit.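

Among these compounds, this is the first measured change at the position para to the methoxy group, and in this assay the exchange of methanesulfonamido for methyl(sulfamoyl)amino is a clear step: an at least 5.4-fold higher number from compound 2 to compound 3 (0.73 log units; beyond the scatter). Compound 3 gives > 50 mg/kg, which is a limit of the assay and not a number. Keeping the chloro group is therefore not enough to give a number here, and the true size of this step stays open: the limit of > 50 mg/kg in this assay, at which 2 of the 3 values shown sit.

The compounds shown leave open whether the methyl group on the nitrogen or the terminal amino group of the sulfamoyl part accounts for the step, as both arrive together in compound 3. Also open, as far as these compounds go, is how a simple amine, a carboxylic acid or the longer ethanesulfonamido chain would read at this position.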